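Ring-chain chloro-ethers: swapping the aromatic substituent

A few compounds are considered here, and "the series" means these few. Any claim that something is new, unique, unknown or untested is made for them only; others in the source may bear on it.

Measured compounds and their values:
compound 1 `CC(C)C[C@H]1C[C@@H](Cl)C[C@@H](C2CCCCC2)O1`: 38000 nM
compound 2 `CC(C)C[C@H]1C[C@@H](Cl)C[C@@H](c2ccccc2)O1`: 35000 nM
compound 3 `CC(C)C[C@H]1C[C@@H](Cl)C[C@@H](c2ccc([N+](=O)[O-])cc2)O1`: 64000 nM

Three compounds share the same saturated oxygen-containing core and differ only in the group attached to it. In a functional assay on A2780 cells (Homo sapiens) for antiproliferative activity (a higher number here means a weaker inhibitor of growth, a lower number a stronger inhibitor of growth), compound 1 gives 38000 nM and compound 2 gives 35000 nM. Compound 3 carries a nitro group on the aromatic ring and gives 64000 nM in this assay, the highest of the three numbers, though all three lie within the scatter of one another, so no order among them can be claimed.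

Going by the values given here, the one step measured here, a 1.8-fold higher number from compound 2 to compound 3 (0.26 log units; within the scatter), changes the same aromatic position and stays within the scatter.

Compound 4 `COc1ccc([C@@H]2C[C@H](Cl)C[C@H](CC(C)C)O2)cc1` is not yet measured. It differs from compound 3 by methoxy in place of nitro on an aromatic carbon. Among the compounds with values here, only the step from compound 2 to compound 3 bears on this change, and it was small. Compound 4 is therefore expected to stay close to compound 3 in this assay, with a step of a 1.4-fold lower number from compound 3 to compound 4 (0.15 log units; within the scatter) and no clear direction beyond the scatter. The estimate for compound 4 in this assay is 45000 nM, expected to fall between 20000 nM and 110000 nM.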

Compound 4, concentration for total growth inhibition: 57000 nM
Beside the measured number, compound 4's estimate is 1.3-fold (0.10 log units) below it, within the range that was stated.
By their numbers in this assay, from the lowest: compounds 2, 1, 4 and 3 (each within the scatter of the next).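

With methoxy on the aromatic carbon para to a large group, this position now carries two different substituents, so each can be read against the unsubstituted ring and against the other. In this assay, exchanging nitro for methoxy gives a small step (a 1.1-fold lower number from compound 3 to compound 4 (0.05 log units; within the scatter)), and methoxy in place of hydrogen also gives a small step (a 1.6-fold higher number from compound 2 to compound 4 (0.21 log units; within the scatter)); with the earlier nitro step, this means that neither group separates from hydrogen or from the other, since every step at this position lies within the scatter. Nothing measured alongside these compounds offers an explanation for these numbers.

What the compounds shown leave open is whether any group at this position can move the number in this assay beyond the scatter, as an amine, a carboxylic acid or a longer chain in the same place might or might not do. They also leave open whether a change elsewhere on the shared core, rather than on the aromatic ring, would produce a step larger than any seen so far.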